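The source may report more compounds than this note shows. Statements on the series, on what has been measured and on what is new or still open speak of the compounds shown alone.

Compound 1 `Cc1cc(C)c(NC(=O)N(Cc2cccc(-c3nn[nH]n3)c2)C2CCCCCC2)c(C)c1` gives > 1000 nM in an assay on microsomes from intestine for inhibition of acyl-CoA:cholesterol acyltransferase (Oryctolagus cuniculus) (a higher number here means a weaker inhibitor, a lower number a stronger inhibitor), which is a limit of the assay and not a number.
Compound 2 `Cc1cc(C)c(NC(=O)N(Cc2ccc(N3CCN(C)CC3)cc2)C2CCCCCC2)c(C)c1` gives 57 nM in this assay.
Compound 3 `O=C(Nc1c(F)cc(F)cc1F)N(Cc1cccc(-c2cc[nH]n2)c1)C1CCCCCC1` gives 22 nM in this assay.

Among the two numbers measured, compound 2 stands highest; the nearest value is that of compound 3, which is lower by an amount beyond the usual scatter. The value for compound 1 sits at the limit (the limit of > 1000 nM in this assay, at which 1 of the 3 values shown sits), so it is known only as a limit.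

Compound 4 `Cc1cc(C)c(NC(=O)N(Cc2ccc(-c3ccsc3)cc2)C2CCCCCC2)c(C)c1` has not yet been measured. It differs from compound 2 in one place: thiophen-3-yl in place of 4-methylpiperazin-1-yl on an aromatic carbon. Among the measured compounds shown here, no measured pair with this same change is available, so the size of the step is open. Only a modest step is expected from compound 2 to compound 4, of uncertain direction and not clearly beyond the scatter, which gives a 1.4-fold higher number from compound 2 to compound 4 (0.15 log units; within the scatter). Compound 4 is therefore estimated to give 80 nM in this assay, within a range from 20 nM to 400 nM.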

Compound 4, half-maximal inhibitory concentration: 19 nM
Estimate against measurement, compound 4: 4.2-fold (0.62 log units) above; measured number outside the range, below it.
By their numbers in this assay, from the lowest: compounds 4 and 3 (each within the scatter of the next); then compound 2. At a limit, above all of these: compound 1.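

Replacing 4-methylpiperazin-1-yl with thiophen-3-yl on the aromatic carbon para to a large group gives a 3.0-fold lower number from compound 2 to compound 4 (0.48 log units; beyond the scatter) in this assay. This pair shows that the non-aromatic ring with two hetero atoms is not required at this position for a number in this range, since a five-membered aromatic ring with one hetero atom, and with fewer heavy atoms, gives a lower number. Nothing measured here accounts for the size or direction of this step.

On these data alone, whether a phenyl ring, a morpholine or a carboxylic acid in this same place would give a lower or a higher number remains open. As far as these compounds go, it is also open whether this change would give a step of similar size on a different core.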